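A cyano group on the phenyl of compound 2

A few compounds are considered here, and "the series" means these few. Any claim that something is new, unique, unknown or untested is made for them only; others in the source may bear on it.

Among the compounds with values here, in a functional assay on HL-60 cells (Homo sapiens) for inhibition, read by MTT assay, with a stated time of 72 h (on this read-out higher numbers stand for weaker inhibition and lower numbers for stronger inhibition), compound 2 `Cc1nc(-c2ccccc2)c(C(=O)N2CCN(c3ccccc3)CC2)o1` gives 39.1 nM and holds the lower of the two numbers so far, which makes it the stronger inhibitor of the pair. Compound 1 `Cc1nc(-c2ccccc2)c(C(=O)N2CCN(c3ccc(Cl)c(Cl)c3)CC2)o1` gives 124 nM in the same test. Compound 3 `Cc1nc(-c2ccccc2)c(C(=O)N2CCN(c3cccc(C#N)c3)CC2)o1` differs from compound 2 in one place, with cyano in place of hydrogen on an aromatic carbon, so that phenyl becomes 3-cyanophenyl. The new group sits meta to a large group. Within the data shown here, the only measured step that bears on this change is a 3.2-fold lower number from compound 1 to compound 2 (0.50 log units; beyond the scatter) when phenyl replaces 3,4-dichlorophenyl on an amine nitrogen in a ring. That step is modest yet beyond the scatter. Read in reverse, it links added groups on that phenyl with a higher number. It rests on a single pair carrying a different substituent, so it is only a weak guide. A modest rise towards weaker inhibition is therefore expected, with a 1.8-fold higher number from compound 2 to compound 3 (0.25 log units; within the scatter) as the estimated step in this assay for this change. For compound 3 the estimated value is 70 nM with 22 nM to 220 nM as the expected range.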

Compound 3, half-maximal inhibitory concentration: 39.6 nM
Compound 3: the middle estimate sits 1.8-fold (0.25 log units) above what was measured, and the stated range covers the measured number.
By their numbers in this assay, from the lowest: compounds 2 and 3 (each within the scatter of the next); then compound 1.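

In this assay placing a cyano group on the phenyl of the earlier compound gives (a 1.0-fold higher number from compound 2 to compound 3 (0.01 log units; within the scatter)), so a carbon meta to a large group on this ring takes that group with no readable change in the number. The swap of 3,4-dichlorophenyl for 3-cyanophenyl gives (a 3.1-fold lower number from compound 1 to compound 3 (0.50 log units; beyond the scatter)), a step beyond the scatter, like the swap to plain phenyl (a 3.2-fold lower number from compound 1 to compound 2 (0.50 log units; beyond the scatter)), so the higher number of compound 1 goes with the 3,4-dichlorophenyl ring and not with every added group on this phenyl, which the first pair alone could not separate. No measurement available here explains either result.

Still open, as far as these compounds go, is whether a single chloro group, a methoxy group, an amine or a carboxylic acid at this same carbon would also leave the number unchanged, which would show how much variety this position accepts. Also open, from the compounds shown here alone, is whether the 3-cyanophenyl result would hold if the methyl group on the shared core gave way to a longer chain.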